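The source may report more compounds than this note shows. Statements on the series, on what has been measured and on what is new or still open speak of the compounds shown alone.

Measured so far: compound 1 `Oc1ccc(-c2cc(-c3ccc(Cl)cc3)nc(-c3cccnc3)c2)cc1`, 22800 nM; compound 2 `Oc1cccc(-c2cc(-c3ccc(Cl)cc3)nc(-c3cccnc3)c2)c1`, 26800 nM.

In a functional assay on DU-145 cells (Homo sapiens) for cytotoxicity, read by CCK-8 assay and cell counting, with a stated time of 2 days (a lower number here means a stronger inhibitor, a higher number a weaker inhibitor), compound 2 gives 26800 nM, and the value of compound 1 sits within the scatter of it: a 1.2-fold higher number from compound 1 to compound 2 (0.07 log units; within the scatter). Compound 3 `Oc1cccc(-c2cc(-c3ccncc3)nc(-c3ccc(Cl)cc3)c2)c1` differs from compound 2 by pyridin-4-yl in place of pyridin-3-yl on an aromatic carbon. Among the measured compounds shown here, the one measured step concerns the hydroxyphenyl group, not the pyridinyl group, so no measured step bears on this change, and nothing beyond the scatter is assumed for it. Compound 3 is therefore expected to give 25000 nM, with a range of 8000 nM to 80000 nM. The expected step is a 1.1-fold lower number from compound 2 to compound 3 (0.03 log units; within the scatter).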

Compound 3, half-maximal inhibitory concentration: 2510 nM
Compound 3: the middle estimate sits 10-fold (1.00 log units) above what was measured; measured number outside the range, below it.
By their numbers in this assay, from the lowest: compound 3; then compounds 1 and 2 (each within the scatter of the next).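

In this assay, among the compounds shown here, this place on the shared core, next to the ring nitrogen, proves sensitive: pyridin-4-yl in place of pyridin-3-yl gives an 11-fold lower number from compound 2 to compound 3 (1.03 log units; beyond the scatter) and is the first change here to go beyond the scatter. The hydroxyphenyl change gave only a 1.2-fold higher number from compound 1 to compound 2 (0.07 log units; within the scatter) by comparison. For the compounds shown here, nothing measured so far accounts for the step.

Still open, on these data alone, is whether the step carries over to the 4-hydroxyphenyl series. A pyridin-2-yl group at this place, or an amine on the pyridine ring, also remains untested in the compounds shown.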